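A Chlorine Added to the Benzyl Group of Compound 2

The source may report more compounds than this note shows. Statements on the series, on what has been measured and on what is new or still open speak of the compounds shown alone.

Of the compounds shown here, two have so far been measured in an assay on Cerebral cortex for displacement of a labelled ligand from adenosine receptor A1 (Bos taurus); on this read-out lower numbers stand for stronger inhibition and higher numbers for weaker inhibition. Compound 1, `OCCNc1nc(-c2ccccc2)nc2c1nnn2Cc1ccccc1Cl`, gives 116 nM in this assay. Compound 2, `OCCCNc1nc(-c2ccccc2)nc2c1nnn2Cc1ccccc1`, gives 21.4 nM in this assay; of the two numbers shown, that of compound 2 is the lower, and the number of compound 1 stands above it by a gap beyond the usual scatter. Among the compounds with values here, compounds 1 and 2 differ in two places at once, so no single step between them can be read off.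

Compound 3, `OCCCNc1nc(-c2ccccc2)nc2c1nnn2Cc1ccccc1Cl`, has not yet been measured. It differs from compound 2 in one place: chloro in place of hydrogen on an aromatic carbon. Compound 1 carries the same chloro group, but it also differs from compound 2 elsewhere, so its value cannot be tied to the chloro alone. Without a matched pair to lean on, a step of modest size from compound 2 to compound 3 is expected, probably toward weaker inhibition, possibly not beyond the scatter. Compound 3 is therefore estimated at 35 nM in this assay, within a range from 12 nM to 110 nM. The expected step is a 1.6-fold higher number from compound 2 to compound 3 (0.21 log units; within the scatter).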

Compound 3, inhibition constant: 33 nM
Estimate against measurement, compound 3: 1.1-fold (0.03 log units) above; the measured number falls inside the stated range.
By their numbers in this assay, from the lowest: compounds 2 and 3 (each within the scatter of the next); then compound 1.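

In this assay, chloro in place of hydrogen on an aromatic carbon, which turns benzyl into 2-chlorobenzyl, gives a 1.5-fold higher number from compound 2 to compound 3 (0.19 log units; within the scatter) and so leaves compound 2 and compound 3 impossible to tell apart on this read-out. Within the data shown here, compound 3 also forms a one-place pair with compound 1, in which hydroxymethyl in place of hydroxy on a saturated chain carbon, two bonds along the chain from a nitrogen on an aromatic ring, gives a 3.5-fold lower number from compound 1 to compound 3 (0.55 log units; beyond the scatter) and is the only single-place step so far beyond the scatter, so in this set the chain end, not the chloro, is the place where the number clearly moves. No independent data explain the size of either step.

On these data alone, the chloro step has been read only on the longer hydroxy chain, so it remains open whether it would hold on the shorter chain of compound 1. Also open, as far as these compounds go, is how this aromatic carbon would take a fluoro, methyl or methoxy group, and how the read-out would respond to a still longer chain or to an amine at the chain end.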